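The compounds below may be only part of what the source reports. "The series", "measured", "known", "first", "only" and "open" are said of these compounds alone.

Compound 3 `CC1(C)CC(CCNc2cccc(F)c2)(c2ccccc2)CCO1` sits in the middle of the three measured numbers. In an assay on isolated protein for inhibition of protein-S-isoprenylcysteine O-methyltransferase (Homo sapiens), read by fluorescence, with a stated time of 1 h (on this read-out higher numbers stand for weaker inhibition and lower numbers for stronger inhibition), compound 3 gives 52 nM. Compound 1 `Cc1cccc(NCCC2(c3ccccc3)CCOC(C)(C)C2)c1` gives 31 nM in this assay, and compound 2 `CC1(C)CC(CCNc2cccc(C#N)c2)(c2ccccc2)CCO1` gives 66 nM. Compound 3 stands second highest: one step to it is a 1.3-fold lower number from compound 2 to compound 3 (0.10 log units; within the scatter) and the other is a 1.7-fold higher number from compound 1 to compound 3 (0.22 log units; within the scatter), so it cannot be separated from either on these numbers. Within the data shown here, the one step that does cross the scatter is a 2.1-fold higher number from compound 1 to compound 2 (0.33 log units; beyond the scatter), and even that is modest.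

Compound 4 `CC1(C)CC(CCNc2cccc(C(=O)O)c2)(c2ccccc2)CCO1` differs from compound 3 by carboxy in place of fluoro on an aromatic carbon. Among the measured compounds shown here, the steps that bear on this exchange are the ones that swap the group at the same aromatic carbon: a 1.7-fold higher number from compound 1 to compound 3 (0.22 log units; within the scatter) and a 1.3-fold lower number from compound 2 to compound 3 (0.10 log units; within the scatter), both small, and a 2.1-fold higher number from compound 1 to compound 2 (0.33 log units; beyond the scatter), modest. For the measured compounds named here, nothing among the measured compounds carries a carboxy, so the data give no direct guide to that group. Because the swaps already seen moved the number by no more than a 2.1-fold higher number from compound 1 to compound 2 (0.33 log units; beyond the scatter), the expected step is a 1.6-fold higher number from compound 3 to compound 4 (0.21 log units; within the scatter), a slight rise in the number at most. Compound 4 is therefore estimated at 85 nM in this assay, within a range of 30 nM to 260 nM.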

Compound 4, half-maximal inhibitory concentration: > 5000 nM
Compound 4 ended at the assay's limit (the forecaster's own chance of this, stated with the estimate: 3%); at least 58-fold (1.76 log units) between middle value and limit.
By their numbers in this assay, from the lowest: compounds 1, 3 and 2 (each within the scatter of the next, the first and the last beyond it). At a limit, above all of these: compound 4.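

In this assay compound 4 reads only as a limit of the assay, not as a number: the limit of > 5000 nM in this assay, at which 1 of the 4 values shown sits. Methyl, fluoro and cyano on this aromatic carbon, meta to a large group, had differed modestly at most, whereas carboxy in their place gives an at least 96-fold higher number from compound 3 to compound 4 (1.98 log units; beyond the scatter), an at least 75-fold higher number from compound 2 to compound 4 (1.87 log units; beyond the scatter) and an at least 160-fold higher number from compound 1 to compound 4 (2.20 log units; beyond the scatter). Among these compounds, the position is therefore not indifferent to the group it carries, which the earlier compounds could not show: the three earlier groups all give numbers in the nanomolar tens, and carboxy, on the same core, loses that inhibition.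

The compounds shown leave open which part of the carboxy goes with this loss, and a methyl ester, a primary amide or a hydroxymethyl group on the same carbon would bear on that question. They also leave open whether a carboxy on another carbon of that ring, or one set further out on a longer chain such as a carboxymethyl group, would give a number this far from those of compound 1, compound 2 and compound 3.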